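Swapping an amine chain for a benzyl group

A few compounds are considered here, and "the series" means these few. Any claim that something is new, unique, unknown or untested is made for them only; others in the source may bear on it.

Measured so far, in a functional assay on MDA-MB-231 cells (Homo sapiens) for cytotoxicity, read by MTT assay, with a stated time of 72 h, tested at 1 uM, in the absence of a further agent; on this read-out higher numbers stand for a weaker effect at the one concentration tested and lower numbers for a stronger effect:
Compound 1, `CC1(C)CC(N)=Nc2ccc(Cl)cc21`, gives 80.5%.
Compound 2, `CN(C)CCCNC1=Nc2ccc(Cl)cc2C(C)(C)C1`, gives 54.1%.
Compound 3, `CN(C)CCNC1=Nc2ccc(Cl)cc2C(C)(C)C1`, gives 66.9%.

Compound 3 stands second highest of the three numbers: compound 1 lies above it, a number 13.6 percentage points lower from compound 1 to compound 3 (beyond the scatter), and compound 2 lies below it, a number 12.8 percentage points higher from compound 2 to compound 3 (beyond the scatter). The step to compound 4, `CC1(C)CC(NCc2ccccc2)=Nc2ccc(Cl)cc21`, is phenyl in place of (dimethylamino)methyl on a saturated chain carbon bound to an amine nitrogen; the same difference, cut one bond further out, reads 2-(dimethylamino)ethyl to benzyl. Among the measured compounds shown here, none of the measured steps puts a phenyl on the chain, so none bears on this change directly. What the measured steps do show is that a chain on the amine nitrogen lowers the number, that is, strengthens the effect: a number 26.4 percentage points lower from compound 1 to compound 2 (beyond the scatter) and a number 13.6 percentage points lower from compound 1 to compound 3 (beyond the scatter), both modest. On that ground compound 4 is expected to remain below compound 1, while its place against compound 3 is open. The expected step is a number 4.9 percentage points lower from compound 3 to compound 4 (within the scatter), small against the scatter. Compound 4 is estimated at 62%, with a range from 45% to 80%.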

Compound 4, a percentage reported as activity, at one concentration (the size of the read-out at that concentration, not a potency): 88.8%
The estimate for compound 4 lay 26.8 percentage points below the measured number, outside the stated range (above it).
By their numbers in this assay, from the lowest: compound 2; then compound 3; then compounds 1 and 4 (each within the scatter of the next).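

In this assay, a chain on the amine nitrogen does not lower the number in every case: benzyl in place of hydrogen gives a number 8.3 percentage points higher from compound 1 to compound 4 (within the scatter) and so leaves the result indistinguishable from the unsubstituted amine of compound 1. Phenyl in place of (dimethylamino)methyl gives a number 21.9 percentage points higher from compound 3 to compound 4 (beyond the scatter) and thus removes the gain seen with compound 3. Phenyl in place of 2-(dimethylamino)ethyl gives a number 34.7 percentage points higher from compound 2 to compound 4 (beyond the scatter) and does the same for compound 2, so among these four compounds only the chains ending in dimethylamino bring the number down.

Still open, on these data alone, is whether a longer chain ending in dimethylamino, or a benzyl group carrying a dimethylamino group on its ring, would lower the number further. No measurement at hand explains why the phenyl swap has this effect.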